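The source may report more compounds than this note shows. Statements on the series, on what has been measured and on what is new or still open speak of the compounds shown alone.

The measured compounds, with their values in an assay on membranes from HeLa cells for displacement of a labelled ligand from adenosine receptor A3 (Homo sapiens), read by scintillation counting, with a stated time of 180 min, tested at 1 uM; a higher number here means more inhibition at the concentration tested (going by the name of the read-out), a lower number less inhibition:
compound 1, `CCCOC(=O)C1=C(C)NC(=S)NC1c1ccsc1`, 1%
compound 2, `CC1=C(C(=O)OCC(C)C)C(c2ccsc2)NC(=S)N1`, 2%
compound 3, `CCCC(=O)C1=C(C)NC(=O)NC1c1ccco1`, 1%

All three values lie within the scatter of one another, so none of these compounds can be told apart in this assay. Compound 1 and compound 2 share a core and differ in one place: methyl in place of hydrogen on a saturated chain carbon bound to two saturated chain carbons. That change gave a number 1 percentage points higher from compound 1 to compound 2 (within the scatter). Compound 3 carries a different core; the difference between the core of compound 3 and the core of compound 1 is not broken down here.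

Compound 4, `CC1=C(C(=O)CC(C)C)C(c2ccco2)NC(=O)N1`, has not yet been measured. Among the compounds with values here, it differs from compound 3 by methyl in place of hydrogen on a saturated chain carbon bound to two saturated chain carbons, which is the same change, at the same kind of place, as the one between compound 1 and compound 2. The expected step is a number 1 percentage points higher from compound 3 to compound 4 (within the scatter), well within the scatter. This expectation rests on the step of a number 1 percentage points higher from compound 1 to compound 2 (within the scatter) made by the same change on another core, and on compound 3 starting at 1%. Compound 4 is therefore estimated at about 2%, expected to fall between -5% and 10%.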

Compound 4, a percentage reported as inhibition, at one concentration (the size of the read-out at that concentration, not a potency): 31%
Beside the measured number, compound 4's estimate is 29 percentage points below it, outside the stated range (above it).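

In this assay, replacing hydrogen with methyl, which turns propylcarbonyl into isobutylcarbonyl, gives a number 30 percentage points higher from compound 3 to compound 4 (beyond the scatter). The same change therefore does not carry over by the same amount from one core to the other: the same change on two cores in this assay, a number 1 percentage points higher (within the scatter) from compound 1 to compound 2 and a number 30 percentage points higher (beyond the scatter) from compound 3 to compound 4, 29 percentage points apart, beyond the scatter of two such steps

These two pairs show that the size of the step depends on the core carrying the change, but they do not show which feature of the two cores makes the difference, why it does, or how the change would behave on a third core.

The compounds shown leave open whether a longer chain, or a chain ending in an amine or a carboxylic acid, would raise the inhibition on the core of compound 3 beyond that of the isobutylcarbonyl group. They also leave open whether either of those groups would produce any clear step on the core of compound 1.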